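The source may report more compounds than this note shows. Statements on the series, on what has been measured and on what is new or still open speak of the compounds shown alone.

Working notes on the series sharing the core of compound 1 (`O=C(Cc1csc2nc(-c3ccc(Br)cc3)cn12)N/N=C/c1ccccc1`). In a functional assay on OVCAR-5 cells (Homo sapiens) for inhibition, read by sulforhodamine B assay, with a stated time of 48 h (a lower number here means a stronger inhibitor of growth, a higher number a weaker inhibitor of growth), compound 1 gives 30900 nM, compound 2 (`O=C(Cc1csc2nc(-c3ccc(Br)cc3)cn12)N/N=C/c1ccccc1O`) gives 5500 nM and compound 3 (`COc1cccc(OC)c1/C=N/NC(=O)Cc1csc2nc(-c3ccc(Br)cc3)cn12`) gives 50100 nM. Compound 3 thus stands at the high-number end of the range, level with compound 1, with a 1.6-fold higher number from compound 1 to compound 3 (0.21 log units; within the scatter). Compound 2 stands apart from it, with a 9.1-fold higher number from compound 2 to compound 3 (0.96 log units; beyond the scatter).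

The next change leads to compound 4 (`O=C(Cc1csc2nc(-c3ccc(Br)cc3)cn12)N/N=C/c1ccc(Cl)cc1Cl`), with 2,4-dichlorophenyl in place of 2,6-dimethoxyphenyl on a carbon with a double bond to nitrogen. Among the measured compounds shown here, no measured compound carries 2,4-dichlorophenyl, so the evidence is indirect. All three measured steps fall at this same place. The phenyl of compound 1 and the 2,6-dimethoxyphenyl of compound 3 differ only within the scatter, while the one clear shift, a 5.6-fold lower number from compound 1 to compound 2 (0.75 log units; beyond the scatter), comes with the hydroxy group of compound 2, which compound 4 lacks. Compound 4 is therefore expected to stay close to compound 1 and compound 3, well short of compound 2. The expected step in this assay is small and towards a lower number, near the edge of the scatter: a 2.3-fold lower number from compound 3 to compound 4 (0.36 log units; beyond the scatter). For compound 4 the estimated value is 22000 nM, with an expected range of 7000 nM to 60000 nM.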

Compound 4, concentration for 50% growth inhibition: 28800 nM
Beside the measured number, compound 4's estimate is 1.3-fold (0.12 log units) below it, and the stated range covers the measured number.
By their numbers in this assay, from the lowest: compound 2; then compounds 4, 1 and 3 (each within the scatter of the next).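

In this assay the 2,4-dichlorophenyl group gives a 1.7-fold lower number from compound 3 to compound 4 (0.24 log units; within the scatter) and also a 1.1-fold lower number from compound 1 to compound 4 (0.03 log units; within the scatter) with no clear shift either way, so this place on a carbon with a double bond to nitrogen now takes phenyl, 2,6-dimethoxyphenyl and 2,4-dichlorophenyl without a clear separation, even though the last two carry different atoms and the 2,6-dimethoxyphenyl has 2 hydrogen-bond acceptors where the 2,4-dichlorophenyl has none. Compound 2 remains the one compound apart, with a 5.2-fold higher number from compound 2 to compound 4 (0.72 log units; beyond the scatter) as its third step beyond the scatter, so among these four compounds only the 2-hydroxyphenyl group separates from the others, and none of the four goes against this. Nothing measured here accounts for the separate standing of compound 2 or for the level standing of the other three.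

As far as these compounds go, all four compounds share the rest of the core of compound 1, so it stays open whether the shift seen with the hydroxy group would survive a change elsewhere in the molecule. From the compounds shown here alone, it is equally open whether an amine, a carboxylic acid or a single methoxy group on the phenyl ring would side with compound 2 or with the other three.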